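A few compounds are considered here, and "the series" means these few. Any claim that something is new, unique, unknown or untested is made for them only; others in the source may bear on it.

Working notes on the shared core, read in a functional assay on the whole organism for inhibition, with Rattus norvegicus as the target, read by cytopathic effect and paw edema, at a dose of 100 mg/kg by the oral route; on this read-out higher numbers stand for more inhibition at the one dose given (going by the name of the read-out) and lower numbers for less inhibition. Compound 1 `CN(C)CCNC(=O)c1c(O)c2cccnc2n(-c2ccccc2)c1=O` gives 18.4%. Compound 2 `Cc1ccccc1NC(=O)c1c(O)c2cccnc2n(-c2ccccc2)c1=O` gives 9.8%, and compound 3 `O=C(Nc1cccnc1)c1c(O)c2cccnc2n(-c2ccccc2)c1=O` gives 30.8%. Compound 1 sits between the other two numbers: towards compound 3 the step is a number 12.4 percentage points higher from compound 1 to compound 3 (beyond the scatter), towards compound 2 it is only a number 8.6 percentage points lower from compound 1 to compound 2 (within the scatter). The step of a number 21 percentage points higher from compound 2 to compound 3 (beyond the scatter) is likewise beyond the scatter.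

Compound 4 `O=C(NCc1ccncc1)c1c(O)c2cccnc2n(-c2ccccc2)c1=O` is not yet measured. From compound 1 it differs by pyridin-4-yl in place of (dimethylamino)methyl on a saturated chain carbon bound to an amide-type nitrogen. The measured steps that bear on this are the two that swap the 2-(dimethylamino)ethyl group on the amide-type nitrogen for a ring: a number 12.4 percentage points higher from compound 1 to compound 3 (beyond the scatter), beyond the scatter, and a number 8.6 percentage points lower from compound 1 to compound 2 (within the scatter), within it. Going by the values given here, compound 4 keeps one saturated chain carbon between the amide-type nitrogen and the ring, so it shares only part of either change, and no measured step brings in a pyridin-4-yl or (pyridin-4-yl)methyl group. A small rise, probably not clearing the scatter, is therefore expected, a number 5.6 percentage points higher from compound 1 to compound 4 (within the scatter). Compound 4 is estimated at 24% in this assay, with a range from 12% to 36%.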

Compound 4, a percentage reported as inhibition, in the whole organism at one dose (the size of the read-out at that dose, not a potency): 15.4%
Compound 4: middle estimate off by 8.6 percentage points, on the high side, and the stated range covers the measured number.
By their numbers in this assay, from the lowest: compounds 2, 4 and 1 (each within the scatter of the next); then compound 3.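

In this assay, the pyridin-4-yl in place of (dimethylamino)methyl on the saturated chain carbon leaves the number within the scatter (a number 3 percentage points lower from compound 1 to compound 4 (within the scatter)), so this exchange of a ring for an open amine does not separate the two compounds. A pyridine ring on the amide side does not by itself go with the higher number: compound 3 stands clear of compound 4 (a number 15.4 percentage points lower from compound 3 to compound 4 (beyond the scatter)), while compound 4 cannot be told apart from compound 2, which has a 2-methylphenyl group and no pyridine ring (a number 5.6 percentage points higher from compound 2 to compound 4 (within the scatter)), and so compound 3 alone stands apart from the other three. Nothing available here explains these differences.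

The step from compound 3 to compound 4 changes both the point at which the pyridine ring is attached and the presence of the chain carbon, so the two contributions remain unseparated; a (pyridin-3-yl)methyl or a directly bound pyridin-4-yl group on the amide-type nitrogen would divide them. Also open, going by these compounds, is how a longer chain, such as 2-(pyridin-4-yl)ethyl, would read at this position.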